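This account rests on a few compounds, and the source may have more. Where it says the series, first, only, none or still open, it means among the compounds named here.

Of the compounds shown here, two built on closely related cores have so far been tested in an ADME assay on BJ cells (Homo sapiens), read by MTT assay, with a stated time of 72 h; on this read-out higher numbers stand for weaker inhibition and lower numbers for stronger inhibition. Compound 1 (`COc1ncnc2c1c(-c1ccccc1)cn2[C@@H]1O[C@H](CO)[C@@H](O)[C@H]1O`) is reported as > 100000 nM, which is a limit of the assay and not a number. Among the measured compounds shown here, compound 2 (`CSc1ncnc2c1c(-c1ccoc1)cn2[C@@H]1O[C@H](CO)[C@@H](O)[C@H]1O`) gives 98800 nM, the only value in this small set that is a true number, so it has no measured neighbour to be ranked against.

Compound 3 (`CSc1ncnc2c1c(-c1cccs1)cn2[C@@H]1O[C@H](CO)[C@@H](O)[C@H]1O`) keeps the core of compound 2 and changes one group, with thiophen-2-yl in place of furan-3-yl on an aromatic carbon. The exchange sits on the five-membered aromatic ring with 1 nitrogen, and both the group that leaves and the group that enters are five-membered aromatic rings with 1 hetero atom. For the measured compounds named here, no measured pair shows what such an exchange does in this assay, so the expectation rests on compound 2 at 98800 nM. The estimated change a 1.4-fold lower number from compound 2 to compound 3 (0.15 log units; within the scatter) is expected to stay within the usual scatter, with no clear direction, and the assay may again report only a limit. Compound 3 is expected at 70000 nM, with an estimated range from 20000 nM to 150000 nM.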

Compound 3, half-maximal inhibitory concentration: 96900 nM
Compound 3: middle estimate off by 1.4-fold (0.14 log units), on the low side; the range from low to high includes it.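

In this assay, the exchange gives a 1.0-fold lower number from compound 2 to compound 3 (0.01 log units; within the scatter), so at this aromatic carbon of the five-membered aromatic ring with 1 nitrogen, furan-3-yl and thiophen-2-yl cannot be told apart. Among the compounds shown here, this is the first step in the set that can be read, as compound 2 alone offered a single number with no measured neighbour, and it covers only this one exchange between five-membered aromatic rings with 1 hetero atom on the core of compound 2. Little room is left above these readings, and for compound 1 the assay gives only a limit: the limit of > 100000 nM in this assay, at which 1 of the 3 values shown sits.

The compounds shown leave open whether a different kind of group at this position, such as an amine, a carboxylic acid or a longer alkyl chain, would shift the number in either direction. They also leave open what the phenyl group of compound 1 does on its own, as compound 1 differs from compound 2 in more than one place and that comparison cannot be read.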